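The source may hold more compounds than are shown below. What is called first, only, known or untested is meant among the compounds shown, and "the series" means these compounds.

Working notes on the shared core, compared in a functional assay on MDA-MB-231 cells (Homo sapiens) for antiproliferative activity, read by MTT assay, with a stated time of 72 h; on this read-out lower numbers stand for stronger inhibition and higher numbers for weaker inhibition. Compound 1 `O=C(Nc1ccc(Cl)cc1)Nc1cccc(-c2nc(-c3ccc(NC(=O)c4cccnc4)cc3Cl)no2)c1` reaches only a limit in this assay, > 10000 nM. Compound 2 `O=C(Nc1cccc(-c2nc(-c3ccc(NC(=O)c4cccnc4)cc3Cl)no2)c1)Nc1cccc(C(F)(F)F)c1` gives 1900 nM in this assay, the highest of the two numbers in hand. Compound 3 `CS(=O)(=O)Nc1ccc(NC(=O)Nc2cccc(-c3nc(-c4ccc(NC(=O)c5cccnc5)cc4Cl)no3)c2)cc1Br` gives 700 nM. Swapping the aryl on the amide-type nitrogen moved the read-out: an at least 5.2-fold lower number from compound 1 to compound 2 (0.72 log units; beyond the scatter), an at least 14-fold lower number from compound 1 to compound 3 (1.15 log units; beyond the scatter) and a 2.7-fold lower number from compound 2 to compound 3 (0.43 log units; beyond the scatter). Compound 4 `O=C(Nc1cccc(-c2nc(-c3ccc(NC(=O)c4cccnc4)cc3Cl)no2)c1)Nc1ccc(NC(=O)c2cccs2)c(C(F)(F)F)c1` differs from compound 2 by ((thiophen-2-yl)carbonyl)amino in place of hydrogen on an aromatic carbon. Within the data shown here, no measured step adds this group; the nearest guide is compound 3, where a 3-bromo-4-(methanesulfonamido)phenyl ring carrying an amide-type hydrogen-bond donor came with a 2.7-fold lower number from compound 2 to compound 3 (0.43 log units; beyond the scatter). A modest lowering of the number is expected for compound 4, a 2.1-fold lower number from compound 2 to compound 4 (0.32 log units; beyond the scatter). Compound 4 is estimated at 900 nM, range 300 nM to 3000 nM.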

Compound 4, half-maximal inhibitory concentration: 2900 nM
Beside the measured number, compound 4's estimate is 3.2-fold (0.51 log units) below it; the range from low to high includes it.
By their numbers in this assay, from the lowest: compound 3; then compounds 2 and 4 (each within the scatter of the next). At a limit, above all of these: compound 1.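

In this assay, ((thiophen-2-yl)carbonyl)amino in place of hydrogen on this aromatic carbon, ortho to a trifluoromethyl group, comes with a 1.5-fold higher number from compound 2 to compound 4 (0.18 log units; within the scatter). Among these compounds, this carbon therefore takes a group of this size with no shift beyond the scatter, which the aryl swaps among the earlier compounds could not show. Nothing measured here bears on a cause for this step. From the compounds shown here alone, whether a plain amine or a carboxylic acid on the same carbon would shift the number beyond the scatter remains open. Also open, going by these compounds, is whether a phenyl ring in place of the thiophene would leave the read-out unchanged.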